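Working notes: methoxycarbonyl side chain on the shared core

The source may hold more compounds than are shown below. What is called first, only, known or untested is meant among the compounds shown, and "the series" means these compounds.

Compound 1 `CN(C)CCCNc1c(C(=O)NCc2ccc(F)cc2)nc(Br)c2cccnc12`: > 10000 nM (a limit)
Compound 2 `NCCNc1c(C(=O)NCc2ccc(F)cc2)nc(Br)c2cccnc12`: > 20000 nM (a limit)

Both entries come from a functional assay on HCT-116 cells (Homo sapiens) for cytotoxicity, read by MTT assay, with a stated time of 72 h (a higher number here means a weaker inhibitor, a lower number a stronger inhibitor), and neither is a number. Compound 2 stands at the limit of > 20000 nM in this assay, at which 1 of the 2 values shown sits. Compound 1 stands at the limit of > 10000 nM in this assay, at which 1 of the 2 values shown sits. Among the measured compounds shown here, the only measured step is a step that the two limits leave unreadable from compound 1 to compound 2, so it offers no size to carry forward.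

Compound 3 `COC(=O)CNc1c(C(=O)NCc2ccc(F)cc2)nc(Br)c2cccnc12` alters the side chain of compound 2, and the core stays the same: methoxycarbonyl in place of aminomethyl on a saturated chain carbon bound to a nitrogen on an aromatic ring. For the measured compounds named here, no measured compound carries a methoxycarbonyl, so the series gives no direct precedent for this change. The expectation can lean only on compound 2, whose > 20000 nM is a limit. On these data alone, no clear step beyond the scatter is expected in this assay, and the direction stays open, although another limit is the most likely report. The estimated at least 1.3-fold lower number from compound 2 to compound 3 (0.12 log units; that floor lies within the scatter) should therefore be read as tentative. For compound 3 the expected value is 15000 nM, with an estimated range of 5000 nM to 40000 nM.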

Compound 3, half-maximal inhibitory concentration: > 10000 nM
Compound 3: only a limit was reported (the forecaster's own chance of this, stated with the estimate: 65%); the middle value does not contradict the limit.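

In this assay compound 3 gives > 10000 nM, which is a limit and not a number. Among the compounds shown here, compound 1 and compound 2 are also reported only as limits, so no step among the three can be read. The compounds shown leave open whether any side chain on the shared core gives a measurable value in this assay.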